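Removing the allyl group from an acetamido aryl ether

A few compounds are considered here, and "the series" means these few. Any claim that something is new, unique, unknown or untested is made for them only; others in the source may bear on it.

Going by the values given here, compound 2 `C=CCc1cc(NC(C)=O)ccc1OCCCNC(C)C` is the one compound here with a measured number in an assay for inhibition of squalene synthase (Rattus norvegicus), using microsomes (a higher number here means a weaker inhibitor, a lower number a stronger inhibitor), where compound 2 gives 65 nM. Compound 1 `CC(C)NCCCOc1ccc(-c2cccnc2)cc1` contributes no number to this assay; in this assay compound 1 gives > 2500 nM, and that value is a limit of the assay rather than a measurement. The other value shown is therefore (the limit of > 2500 nM in this assay, at which 1 of the 2 values shown sits). Among the compounds with values here, compound 2 thus stands alone as the single fixed point from which anything about the series can be judged, with no measured pair to show the size or direction of any change.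

Compound 3 `CC(=O)Nc1ccc(OCCCNC(C)C)cc1` differs from compound 2 by hydrogen in place of allyl on an aromatic carbon, in other words hydrogen in place of allyl on an aromatic carbon. Within the data shown here, since no measured step covers this change, the expectation rests on compound 2 alone. The expected step of a 3.1-fold higher number from compound 2 to compound 3 (0.49 log units; beyond the scatter) is a moderate move toward weaker inhibition, somewhat beyond the usual scatter. Compound 3 is accordingly estimated at 200 nM, with a range from 60 nM to 800 nM.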

Compound 3, half-maximal inhibitory concentration: > 2500 nM
Compound 3: no number, only a limit; the forecaster's own chance of this, stated with the estimate: 10%; at least 12-fold (1.09 log units) between middle value and limit.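

Putting hydrogen in place of allyl gives an at least 38-fold higher number from compound 2 to compound 3 (1.58 log units; beyond the scatter), which shows that in this assay this aromatic carbon, ortho to a group of 8 heavy atoms and meta to the acetamido group, is not a site where the allyl group can be dropped without loss. In this assay, from the compounds shown here alone, compound 3 gives > 2500 nM, and that value is a limit of the assay, so the step gives only the smallest size the change can have, and its true size stays unknown. The step from compound 1 to compound 3 cannot be read, because both values are limits: the limit of > 2500 nM in this assay, at which 2 of the 3 values shown sit.

Going by these compounds, what stays open is whether the allyl group matters through its double bond or through its three carbons, which a saturated propyl group or a shorter methyl group at the same carbon would help to separate. Also open, on these data alone, is what the acetamido group contributes while the allyl group stays in place, a question that a free amine or a carboxylic acid at that position could address.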